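Swapping 2-methylphenyl for 4-methylbenzyl in compound 1

The source may report more compounds than this note shows. Statements on the series, on what has been measured and on what is new or still open speak of the compounds shown alone.

- compound 1 `Cc1ccccc1Nc1nc(Nc2ccc(N3CCN(C)CC3)cn2)ncc1Cl`: 5210 nM
- compound 2 `Cc1ccccc1Nc1nc(Nc2ccc(N3CCNCC3)cn2)ncc1Cl`: 3410 nM
- compound 3 `Cc1ccccc1Nc1nc(Nc2ccc(N3CCCCC3)cn2)ncc1Cl`: 21400 nM

In a functional assay on MCF7 cells (Homo sapiens) for inhibition, read by CCK-8 assay, with a stated time of 48 h (on this read-out lower numbers stand for stronger inhibition of growth and higher numbers for weaker inhibition of growth), compound 1 gives 5210 nM. It stands level with compound 2, as a 1.5-fold lower number from compound 1 to compound 2 (0.18 log units; within the scatter) shows, and apart from compound 3, as a 4.1-fold higher number from compound 1 to compound 3 (0.61 log units; beyond the scatter) shows. The remaining step, a 6.3-fold higher number from compound 2 to compound 3 (0.80 log units; beyond the scatter), is of similar modest size.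

Compound 4 `Cc1ccc(CNc2nc(Nc3ccc(N4CCN(C)CC4)cn3)ncc2Cl)cc1` differs from compound 1 at another place: 4-methylbenzyl in place of 2-methylphenyl on a nitrogen on an aromatic ring. In words, this is 4-methylbenzyl in place of 2-methylphenyl on a nitrogen on an aromatic ring. All three measured steps leave the 2-methylphenyl group untouched, so none of them bears directly on this change, and the data give no direction for it. Compound 4 keeps the 4-methylpiperazin-1-yl group of compound 1, so the expectation starts from the 5210 nM of compound 1, with a wide margin. The expected result is a 1.2-fold higher number from compound 1 to compound 4 (0.06 log units; within the scatter), no step beyond the scatter. For compound 4 the estimated value is 6000 nM, within an expected range of 2000 nM to 20000 nM.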

Compound 4, concentration for 50% growth inhibition: 38100 nM
Compound 4: the middle estimate sits 6.4-fold (0.80 log units) below what was measured; the whole stated range lies below it.
By their numbers in this assay, from the lowest: compounds 2 and 1 (each within the scatter of the next); then compounds 3 and 4 (each within the scatter of the next).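

In this assay, the swap on the nitrogen on the aromatic ring gives (a 7.3-fold higher number from compound 1 to compound 4 (0.86 log units; beyond the scatter)), the first step shown that touches the 2-methylphenyl group rather than the group carried at the 4-methylpiperazin-1-yl place. It shows that this nitrogen's substituent also moves the number beyond the scatter, and that the step belongs to the same modest class as (a 6.3-fold higher number from compound 2 to compound 3 (0.80 log units; beyond the scatter)). Nothing available here bears on why the number rises with this change.

The step replaces 2-methylphenyl with 4-methylbenzyl in one move, so 2-methylbenzyl or 4-methylphenyl on the same nitrogen would be needed to tell which part of the change goes with the higher number. Going by these compounds, it also remains open whether the same swap would give a step of like size on the piperazin-1-yl group of compound 2.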